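The source may hold more compounds than are shown below. What is called first, only, known or untested is meant among the compounds shown, and "the series" means these compounds.

Measured in a functional assay on MLM cells (Homo sapiens) for cytotoxicity, using microsomes; on this read-out higher numbers stand for an effect only at larger amounts of compound and lower numbers for an effect already at smaller amounts:
compound 1 `COc1cc(/C=C\c2ccc(C(C)C)cc2)cc(OC)c1OC`: 7 uM
compound 2 `CCOc1ccc(/C=C\c2cc(OC)c(OC)c(OC)c2)cc1`: 2.9 uM
compound 3 `CCCOc1ccc(/C=C\c2cc(OC)c(OC)c(OC)c2)cc1`: 6.5 uM

Compound 3, at 6.5 uM, stands with compound 1 at the upper end of these three numbers, with a 1.1-fold lower number from compound 1 to compound 3 (0.03 log units; within the scatter). Compound 2 lies lower, with a 2.2-fold higher number from compound 2 to compound 3 (0.35 log units; beyond the scatter).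

The next compound, compound 4 `COc1cc(/C=C\c2ccc(SC)cc2)cc(OC)c1OC`, differs from compound 3 in one place: methylsulfanyl in place of propoxy on an aromatic carbon. Methylsulfanyl takes the place of propoxy on an aromatic carbon, para to a large group. Among the measured compounds shown here, no measured compound carries methylsulfanyl, so the evidence is indirect. It comes from the other exchanges at this place, which gave a 2.4-fold lower number from compound 1 to compound 2 (0.38 log units; beyond the scatter) and a 1.1-fold lower number from compound 1 to compound 3 (0.03 log units; within the scatter). Among the alkoxy groups, the step between ethoxy and propoxy was also modest. These steps suggest only a small change here, leaning slightly towards a lower number, since compound 2, with the shorter ethoxy, gives 2.9 uM. The expected change is a 1.6-fold lower number from compound 3 to compound 4 (0.21 log units; within the scatter). The estimate for compound 4 is 4 uM, with an expected range of 1.5 uM to 10 uM.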

Compound 4, concentration for half-maximal effect: 3.3 uM
Compound 4: the middle estimate sits 1.2-fold (0.08 log units) above what was measured; measured number inside the range.
By their numbers in this assay, from the lowest: compounds 2, 4, 3 and 1 (each within the scatter of the next, the first and the last beyond it).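

In this assay, among the compounds shown here, methylsulfanyl is the first group at this place, on an aromatic carbon para to a large group, that is joined through sulfur, and its exchange for propoxy gives a 2.0-fold lower number from compound 3 to compound 4 (0.29 log units; within the scatter) and so cannot be told from no change. Against ethoxy the same group gives a 1.1-fold higher number from compound 2 to compound 4 (0.06 log units; within the scatter) and against isopropyl it gives a 2.1-fold lower number from compound 1 to compound 4 (0.33 log units; beyond the scatter) and this places compound 4 within the scatter of both compound 2 and compound 3, two compounds that are themselves told apart, while it remains separate from compound 1, though only modestly. (Nothing shown here explains why these exchanges give the numbers they do)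

The four compounds span a narrow band and leave open whether sulfur itself matters at this place, which a longer thioether such as ethylsulfanyl, set against ethoxy and propoxy, would begin to address. They also leave open how this place would respond to a quite different group, such as an amine, a carboxylic acid or a chlorine atom, since only alkyl, alkoxy and methylsulfanyl groups appear here.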